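The source may hold more compounds than are shown below. What is called first, only, known or untested is meant among the compounds shown, and "the series" means these compounds.

Measured compounds:

compound 1 `O=c1cc(Cn2cc(CCc3ccccc3)nn2)c2ccc(O)cc2o1` gives 24800 nM in a functional assay on A549 cells (Homo sapiens) for inhibition, read by MTT assay, with a stated time of 72 h; a lower number here means a stronger inhibitor, a higher number a weaker inhibitor
compound 2 `Cc1ccc(S(=O)(=O)NCc2cn(Cc3cc(=O)oc4cc(O)ccc34)nn2)cc1` gives 46400 nM in this assay

Of the two numbers shown, compound 2 has the highest, but its gap to compound 1 is within the usual scatter, so the two cannot be told apart on these data. Compound 3 `O=c1cc(Cn2cc(CNS(=O)(=O)c3ccc([N+](=O)[O-])cc3)nn2)c2ccc(O)cc2o1` has not yet been measured. It differs from compound 2 in one place: nitro in place of methyl on an aromatic carbon, a nitro in place of methyl on an aromatic carbon. Both measured compounds are weak inhibitors, and no comparable change between measured compounds exists here to say how a nitro instead of a methyl shifts the number. The step from compound 2 to compound 3 is therefore expected to be small, in no clear direction, and most likely not beyond the scatter, as a 1.2-fold lower number from compound 2 to compound 3 (0.06 log units; within the scatter) shows. Compound 3 is expected to give about 40000 nM in this assay, with a plausible range from 15000 nM to 110000 nM.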

Compound 3, half-maximal inhibitory concentration: > 100000 nM
Compound 3 gave a limit, no number; the forecaster's own chance of this, stated with the estimate: 20%; middle value at least 2.5-fold (0.39 log units) away from the limit.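

Nitro in place of methyl on the aromatic ring, the change from 4-methylphenyl to 4-nitrophenyl, brings an at least 2.1-fold higher number from compound 2 to compound 3 (0.33 log units; beyond the scatter) in this assay. A higher number means a weaker inhibitor, so this position, para to a large group, does respond to the group placed on it, and here the response is toward weaker inhibition; the two earlier compounds differ in more than one place and could not show this. Compound 3 gave a limit and not a number, so the step is a lower bound and its full size stays unknown: the limit of > 100000 nM in this assay, at which 1 of the 3 values shown sits.

A single change at this position cannot tell whether the methyl helps, the nitro harms, or both. The compounds shown also leave open how a bare hydrogen, an amine or a carboxylic acid at this position would compare with methyl and nitro.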